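N-Methylation across two quinolone cores in permeability

This account rests on a few compounds, and the source may have more. Where it says the series, first, only, none or still open, it means among the compounds named here.

Compound 1 `Cc1[nH]c2ccc(Cl)cc2c(=O)c1Cc1ccccc1` and compound 3 `Cc1c(Cc2ccccc2)c(=O)c2cc(Cl)ccc2n1C` share one core; compound 2 `COc1ccc2c(=O)c(Cc3ccccc3)c(C)[nH]c2c1` carries a second core, and the difference between the two cores is not broken down here. In an ADME assay for permeability, using PAMPA, at pH 4 (a higher number here means that the compound crosses the layer faster, a lower number that the compound crosses the layer more slowly), compound 1 gives 422 10^-6 cm/s, and compound 3 gives 510 10^-6 cm/s. The change between them is methyl in place of hydrogen on an aromatic nitrogen, and its step is a 1.2-fold higher number from compound 1 to compound 3 (0.08 log units; within the scatter). In this assay compound 2 gives 200 10^-6 cm/s, which stands as the lowest of the three numbers, beyond the scatter from both of the others.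

Compound 4 `COc1ccc2c(=O)c(Cc3ccccc3)c(C)n(C)c2c1` is not yet measured. It differs from compound 2 by methyl in place of hydrogen on an aromatic nitrogen, the same change as from compound 1 to compound 3, at a place described in the same words. Among the compounds with values here, the only guide to its effect is the single step from compound 1 to compound 3 in this assay; one occurrence on one core is a thin basis.

From compound 2 to compound 4 the step in this assay is expected to be about a 1.2-fold higher number from compound 2 to compound 4 (0.08 log units; within the scatter), resting on a 1.2-fold higher number from compound 1 to compound 3 (0.08 log units; within the scatter). Compound 4 is therefore estimated at 240 10^-6 cm/s, with a plausible range from 130 10^-6 cm/s to 430 10^-6 cm/s.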

Compound 4, apparent permeability: 432 10^-6 cm/s
Compound 4: middle estimate off by 1.8-fold (0.26 log units), on the low side; the measured number lies above the stated range.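

In this assay, methyl in place of hydrogen on an aromatic nitrogen of the second core gives a 2.2-fold higher number from compound 2 to compound 4 (0.33 log units; beyond the scatter). Set beside the same change on the first core, this step does not differ from the earlier one by more than the scatter allows: the same change on two cores in this assay, a 1.2-fold higher number (0.08 log units; within the scatter) from compound 1 to compound 3 and a 2.2-fold higher number (0.33 log units; beyond the scatter) from compound 2 to compound 4, 1.8-fold (0.25 log units) apart, within the scatter of two such steps

So the notes can treat the change as carrying from one core to the other without any demonstrated dependence on the core, though this rests on one pair per core. Within the data shown here, this does not fix a size for the change, since only one of the two steps lies beyond the scatter, and it neither proves that the cores respond alike nor excludes a real difference smaller than the scatter can resolve.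

Still open, going by these compounds, is whether a longer chain, such as ethyl, or a chain ending in an amine or a carboxylic acid, on the same aromatic nitrogen would follow these two steps. Also open, on these data alone, is how the change behaves on cores carrying groups other than the chlorine of compound 1 and the methoxy of compound 2.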